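Halogen swap on the anilide ring: bromo to iodo

The source may report more compounds than this note shows. Statements on the series, on what has been measured and on what is new or still open speak of the compounds shown alone.

Compound 1 `S=C(Nc1ccccc1)OCCc1ccccn1` carries hydrogen on the aromatic carbon in question. In an ADME assay on MT4 cells (Homo sapiens) for cytotoxicity, read by MTT assay (on this read-out higher numbers stand for lower toxicity in this test and lower numbers for higher toxicity in this test), compound 1 reaches only a limit, > 100000 nM. Compound 2 `S=C(Nc1ccc(Br)cc1)OCCc1ccccn1` carries bromo instead, and in this assay compound 2 gives 37000 nM. Compound 2 thus holds the only number shown in this assay. The other value shown is a limit, that of compound 1 (the limit of > 100000 nM in this assay, at which 1 of the 2 values shown sits). Among the measured compounds shown here, the one measured step, an at least 2.7-fold lower number from compound 1 to compound 2 (0.43 log units; beyond the scatter), concerns bromo entering in place of hydrogen. Compound 3 `S=C(Nc1ccc(I)cc1)OCCc1ccccn1` differs from compound 2 by iodo in place of bromo on an aromatic carbon. The measured step bears on this change only loosely, since it replaces one halogen with another rather than adding one; a smaller step in the same direction is expected. In this assay the expected step is a 1.5-fold lower number from compound 2 to compound 3 (0.17 log units; within the scatter). Compound 3 is accordingly expected to give 25000 nM in this assay, with a range from 10000 nM to 60000 nM.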

Compound 3, half-maximal cytotoxic concentration: 34000 nM
The estimate for compound 3 lay 1.4-fold (0.13 log units) below the measured number, and the stated range covers the measured number.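

In this assay, bromo and iodo cannot be told apart at this position, para to a large group: the step is a 1.1-fold lower number from compound 2 to compound 3 (0.04 log units; within the scatter). Iodo in place of hydrogen gives an at least 2.9-fold lower number from compound 1 to compound 3 (0.46 log units; beyond the scatter), so compound 3 now stands with compound 2 as a second halogen compound on the lower side of the unsubstituted compound 1, with no exception among the three compounds shown. Compound 1 reports a limit and not a number, so the full size of the steps from it cannot be read: the limit of > 100000 nM in this assay, at which 1 of the 3 values shown sits.

Going by these compounds, what a fluoro or chloro group, or an amine, would give at this position remains open. Also open, on these data alone, is whether a longer chain in place of the ethyl link to the pyridine-bearing end would alter these numbers.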